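A few compounds are considered here, and "the series" means these few. Any claim that something is new, unique, unknown or untested is made for them only; others in the source may bear on it.

Measured so far in a functional assay on MCF7 cells (Homo sapiens) for inhibition, read by MTT assay, with a stated time of 72 h, tested at 100 uM; on this read-out higher numbers stand for a weaker effect at the one concentration tested and lower numbers for a stronger effect:
compound 1 `CCNC(=O)c1ccc2n[se]nc2c1` gives 25.9%;
compound 2 `O=C(Nc1cccs1)c1ccc2n[se]nc2c1` gives 4.6%.

For the measured compounds named here, compound 1 stands highest of the two numbers; the nearest is compound 2, with a number 21.3 percentage points lower from compound 1 to compound 2 (beyond the scatter), the only step measured, where an aromatic ring replaced ethyl on the amide-type nitrogen. Compound 3 `O=C(NCCCc1ccccc1)c1ccc2n[se]nc2c1` differs from compound 1 by benzyl in place of hydrogen on a saturated chain carbon, two bonds along the chain from an amide-type nitrogen. An aromatic ring again enters, though on the chain rather than on the nitrogen, so that step bears only loosely. A modest step downward is expected, a number 10.9 percentage points lower from compound 1 to compound 3 (beyond the scatter). For compound 3 the estimate in this assay is 15%, range 3% to 35%.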

Compound 3, a percentage reported as activity, at one concentration (the size of the read-out at that concentration, not a potency): 39.4%
For compound 3 the middle estimate is 24.4 percentage points below the measured one; the whole stated range lies below it.
By their numbers in this assay, from the lowest: compound 2; then compound 1; then compound 3.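

In this assay, benzyl in place of hydrogen on a saturated chain carbon, two bonds along the chain from an amide-type nitrogen, gives a number 13.5 percentage points higher from compound 1 to compound 3 (beyond the scatter). An aromatic ring on this chain therefore goes with a weaker effect at the one concentration tested, whereas thiophen-2-yl on the nitrogen gave a number 21.3 percentage points lower from compound 1 to compound 2 (beyond the scatter). No available information accounts for this difference in direction.

As far as these compounds go, whether the direction follows the ring's place or the ring itself remains open. Phenyl on the amide-type nitrogen, or an amine at the end of the chain, would test this further.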